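The compounds below may be only part of what the source reports. "The series", "measured", "known", "first", "only" and "open" are said of these compounds alone.

Compound 1 `CCN1CCN(C[C@H]2CN(c3ccc(-n4cc(-c5ccccn5)cn4)c(F)c3)C(=O)O2)CC1` and compound 2 `COC(=O)CC1CCN(C[C@H]2CN(c3ccc(-n4cc(-c5ccccn5)cn4)c(F)c3)C(=O)O2)CC1` share one core and differ only in the group on a saturated chain carbon bound to a saturated ring carbon. In an ADME assay on L02 cells (Homo sapiens) for cytotoxicity, read by MTT assay, with a stated time of 48 h (a lower number here means a stronger inhibitor, a higher number a weaker inhibitor), compound 1 gives 99 ug/mL. Compound 2, in this assay, reaches only a limit, > 400 ug/mL, so the change an at least 4.0-fold higher number from compound 1 to compound 2 (0.60 log units; beyond the scatter) is known only as a lower bound; the record notes (the limit of > 400 ug/mL in this assay, at which 1 of the 2 values shown sits). Compound 3 `O=C1CCC(=O)N1C[C@H]1CN(c2ccc(-n3cc(-c4ccccn4)cn3)c(F)c2)C(=O)O1` follows from compound 2 by 2,5-dioxopyrrolidin-1-yl in place of 4-((methoxycarbonyl)methyl)piperidin-1-yl on a saturated chain carbon bound to a saturated ring carbon. Among the compounds with values here, only one measured step bears on it, the move from compound 1 to compound 2 at the group on this chain carbon, which raised the number at least modestly and left compound 2 at a limit. Within the data shown here, with no other step at this position, the expectation for compound 3 is a number near where compound 2 stands, with the step of an at least 1.1-fold lower number from compound 2 to compound 3 (0.05 log units; that floor lies within the scatter) expected to lie within the scatter. Compound 3 is therefore estimated at 350 ug/mL, within 120 ug/mL to 800 ug/mL.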

Compound 3, half-maximal inhibitory concentration: > 400 ug/mL
Compound 3 ended at the assay's limit; the forecaster's own chance of this, stated with the estimate: 55%; middle value at least 1.1-fold (0.05 log units) from the limit.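

In this assay compound 3 also reaches only a limit, > 400 ug/mL, not a number. With 2,5-dioxopyrrolidin-1-yl in place of 4-ethylpiperazin-1-yl on this saturated chain carbon, the result is an at least 4.0-fold higher number from compound 1 to compound 3 (0.60 log units; beyond the scatter), so a second, quite different group now gives a rise beyond the scatter, and the rise is no longer tied to 4-((methoxycarbonyl)methyl)piperidin-1-yl alone. The step between compound 2 and compound 3 cannot be read, because both sit at the same limit: the limit of > 400 ug/mL in this assay, at which 2 of the 3 values shown sit.

The compounds shown leave open how far past the limit either compound lies, so the two groups cannot be ordered. They also leave open whether the lower number belongs to 4-ethylpiperazin-1-yl in particular, or whether another amine, such as morpholine, or a carboxylic acid in place of the methyl ester would give a readable value at this position.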